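This account rests on a few compounds, and the source may have more. Where it says the series, first, only, none or still open, it means among the compounds named here.

Compound 1 has the structure `Cc1cccc(C)c1NC(=O)CSc1nnc(-c2ccoc2C)n1Cc1ccco1`. In a functional assay on CHO cells for antagonist activity at Orexin/Hypocretin receptor type 1 (Homo sapiens), read by FLIPR and calcium flux (a higher number here means a weaker inhibitor, a lower number a stronger inhibitor), compound 1 gives > 15800 nM, which is a limit of the assay rather than a number. Compound 2, `Cc1cccc(NC(=O)CSc2nnc(-c3ccoc3C)n2Cc2ccco2)c1C`, carries a 2,3-dimethylphenyl in place of the 2,6-dimethylphenyl on the amide-type nitrogen. In this assay compound 2 gives > 15800 nM, again a limit. Compound 3, `Cc1occc1-c1nnc(SCC(=O)Nc2cccc(F)c2)n1Cc1ccco1`, carries a 3-fluorophenyl on that nitrogen. In this assay compound 3 gives > 15800 nM, also a limit. So the three steps, a step that the two limits leave unreadable from compound 1 to compound 2, a step that the two limits leave unreadable from compound 1 to compound 3 and a step that the two limits leave unreadable from compound 2 to compound 3, cannot be sized; all that is known is that every value shown sits at the limit of > 15800 nM in this assay, at which 3 of the 3 values shown sit.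

Compound 4, `Cc1occc1-c1nnc(SCC(=O)Nc2ccc(Cl)cc2)n1Cc1ccco1`, differs from compound 1 by 4-chlorophenyl in place of 2,6-dimethylphenyl on an amide-type nitrogen. The measured steps that bear on this change are exactly those swapping the group on the amide-type nitrogen, and none of them is readable, since each compound only reaches the limit. Three aryl groups of different shape and substitution pattern have all left the series without measurable inhibition, and a 4-chlorophenyl is a fourth such group. Compound 4 is therefore expected to stay at the limit as well, with an estimate of 30000 nM and a range from 10000 nM to 100000 nM. This estimate means an expected step that the limit leaves unreadable from compound 1 to compound 4.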

Compound 4, inhibition constant: 2000 nM
The estimate for compound 4 lay 15-fold (1.18 log units) above the measured number; the measured number lies below the stated range.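

In this assay, the group on the amide-type nitrogen can carry measurable inhibition: with the rest of the molecule unchanged, 4-chlorophenyl gives the only real number among the compounds shown. The change appears as an at least 7.9-fold lower number from compound 1 to compound 4 (0.89 log units; beyond the scatter), as an at least 7.9-fold lower number from compound 2 to compound 4 (0.89 log units; beyond the scatter) and as an at least 7.9-fold lower number from compound 3 to compound 4 (0.89 log units; beyond the scatter), and each of these sizes is only a minimum, as the starting end of each step is a limit and not a number. The steps among compound 1, compound 2 and compound 3 still cannot be read, so compound 4 alone stands apart, and a single compound makes no trend: the limit of > 15800 nM in this assay, at which 3 of the 4 values shown sit.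

The compounds shown leave open whether the gain comes from the chlorine itself or from its place on the ring, as the 3-fluorophenyl of compound 3 differs from the 4-chlorophenyl of compound 4 in both respects. A 3-chlorophenyl and a 4-fluorophenyl on the same nitrogen would separate these two changes, while a 4-methoxyphenyl would test whether a halogen is needed at all.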